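This account rests on a few compounds, and the source may have more. Where it says the series, first, only, none or still open, it means among the compounds named here.

Compound 3 `COc1ccc(F)cc1CNCCCNc1ccnc2cc(-c3ccc(C(C)(C)C)cc3)ccc12` gives 620 nM in an ADME assay on HepG2 cells (Homo sapiens) for cytotoxicity, read by luminescence, CellTiter-Glo and ATP content, with a stated time of 72 h (on this read-out lower numbers stand for an effect already at smaller amounts and higher numbers for an effect only at larger amounts of compound), the lowest of the three numbers measured. Compound 1 `COc1ccc(F)cc1CNCCCNc1ccnc2cc(-c3ccc(F)cc3)ccc12` gives 770 nM and lies within the scatter of compound 3; compound 2 `COc1ccc(F)cc1CNCCCNc1ccnc2cc(-c3cccc4ccccc34)ccc12` gives 16000 nM and lies well beyond it. The step from compound 3 to compound 4 `COc1ccc(F)cc1CNCCCNc1ccnc2cc(Cc3cccc(C(F)(F)F)c3)ccc12` is 3-(trifluoromethyl)benzyl in place of 4-(tert-butyl)phenyl on an aromatic carbon. Going by the values given here, two measured steps bear on it. The step of a 1.2-fold lower number from compound 1 to compound 3 (0.09 log units; within the scatter) shows that exchanging the substituent on the pendant phenyl group leaves the number essentially unchanged. The steps of a 21-fold higher number from compound 1 to compound 2 (1.32 log units; beyond the scatter) and a 26-fold lower number from compound 2 to compound 3 (1.41 log units; beyond the scatter) show that replacing the pendant phenyl group itself by a larger aromatic system moves the number a great deal. Compound 4 keeps a single six-membered aromatic ring but attaches it through a benzyl group rather than directly, a change without precedent in the series, so an expected modest upward step of a 2.4-fold higher number from compound 3 to compound 4 (0.38 log units; beyond the scatter) is taken, with wide uncertainty. Compound 4 is therefore estimated at 1500 nM, with a range from 400 nM to 6000 nM.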

Compound 4, half-maximal effective concentration in the HepG2 assay: 440 nM
Beside the measured number, compound 4's estimate is 3.4-fold (0.53 log units) above it; the measured number falls inside the stated range.
By their numbers in the HepG2 assay, from the lowest: compounds 4, 3 and 1 (each within the scatter of the next); then compound 2.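

In the HepG2 assay, the 3-(trifluoromethyl)benzyl group cannot be told apart from the directly attached aryl groups, with a 1.4-fold lower number from compound 3 to compound 4 (0.15 log units; within the scatter) and a 1.8-fold lower number from compound 1 to compound 4 (0.24 log units; within the scatter), so a benzyl group at this aromatic carbon reads the same as 4-(tert-butyl)phenyl and 4-fluorophenyl. Among the four compounds, naphthalen-1-yl alone stands apart, with a 36-fold lower number from compound 2 to compound 4 (1.56 log units; beyond the scatter). In a physicochemical assay for solubility, with a stated time of 18 h, at pH 7.4 (a higher number here means a more soluble compound, a lower number a less soluble compound), compound 3 gives 32000 nM and compound 4 gives 4200 nM, so an exchange that is silent on cytotoxicity lowers solubility: the measured solubility of compound 3, 32000 nM, and of compound 4, 4200 nM, a 7.6-fold lower number (0.88 log units; beyond the scatter)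

The compounds shown do not separate the benzyl link from the trifluoromethyl group in either read-out. From the compounds shown here alone, how both read-outs respond to an amine or a carboxylic acid on the benzyl ring, or to a longer chain such as 2-phenylethyl at this position, remains open.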